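A Second Fluorine Replaces a Methoxy Group

The source may hold more compounds than are shown below. What is called first, only, known or untested is meant among the compounds shown, and "the series" means these compounds.

Of the compounds shown here, three sharing one core have been measured in a functional assay on M14 cells (Homo sapiens) for antiproliferative activity, with a stated time of 72 h; a lower number here means a stronger inhibitor, a higher number a weaker inhibitor. Compound 1 `C=CC[C@H]1C[C@]2([C@@H](C)Cc3ccc(OC)c(OC)c3)OCOC2=CC1=O` gives 110 nM. Compound 2 `C=CC[C@H]1C[C@]2([C@@H](C)Cc3ccc(OC(F)(F)F)cc3)OCOC2=CC1=O` gives > 20000 nM, which is a limit of this assay rather than a number. Compound 3 `C=CC[C@H]1C[C@]2([C@@H](C)Cc3cc(OC)c(OC)cc3F)OCOC2=CC1=O` gives 14 nM, the lowest of the two numbers shown, with compound 1 the nearest at a 7.9-fold lower number from compound 1 to compound 3 (0.90 log units; beyond the scatter). Among the measured compounds shown here, that single step, fluoro in place of hydrogen on an aromatic carbon, is the only measured change between numbers.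

Compound 4 `C=CC[C@H]1C[C@]2([C@@H](C)Cc3cc(F)c(OC)cc3F)OCOC2=CC1=O` differs from compound 3 in one place: fluoro in place of methoxy on an aromatic carbon. For the measured compounds named here, no measured step exchanges a methoxy for a fluoro, so the earlier step offers no direct guide. Compound 1 and compound 3 both carry two methoxy groups, while compound 2, which carries none, gives only a limit; losing one methoxy is therefore expected to raise the number in this assay. The expected step is a 7.1-fold higher number from compound 3 to compound 4 (0.85 log units; beyond the scatter). Compound 4 is estimated at 100 nM, within a range from 20 nM to 800 nM.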

Compound 4, half-maximal inhibitory concentration: 30 nM
Beside the measured number, compound 4's estimate is 3.3-fold (0.52 log units) above it; the range from low to high includes it.
By their numbers in this assay, from the lowest: compound 3; then compound 4; then compound 1. At a limit, above all of these: compound 2.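

The methoxy group at this position is not required for activity in this assay: with fluoro in its place, compound 4 still gives 30 nM. The exchange carries a modest cost (a 2.1-fold higher number from compound 3 to compound 4 (0.33 log units; beyond the scatter)), which is a real change but leaves the compound active. The earlier step showed only a hydrogen on the aromatic ring giving way to fluoro, whereas this one shows that a group already on that ring, ortho to the remaining methoxy and para to the first fluoro, can also be exchanged.

Nothing among the data shown explains why the exchange costs this much. Also open, going by these compounds, is how this position would respond to a hydroxyl, an amine or a longer chain such as ethoxy, and whether the remaining methoxy group can be exchanged in the same way.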